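Taking the bromo group off compound 2

The source may report more compounds than this note shows. Statements on the series, on what has been measured and on what is new or still open speak of the compounds shown alone.

Measured so far in a functional assay on DU-145 cells (Homo sapiens) for antiproliferative activity, read by MTT assay, with a stated time of 48 h; a lower number here means a stronger inhibitor, a higher number a weaker inhibitor:
Compound 1 `C/C(=C\CC/C(C)=C/CC[C@@H]1[C@@]2(C)CCC(=O)C(C)(C)[C@H]2CC[C@@]1(C)O)CC/C=C(\C)C(=O)OCc1cn(-c2ccc(F)c(Cl)c2)nn1`: > 150000 nM
Compound 2 `C/C(=C\CC/C(C)=C/CC[C@@H]1[C@@]2(C)CCC(=O)C(C)(C)[C@H]2CC[C@@]1(C)O)CC/C=C(\C)C(=O)OCc1cn(-c2cccc(Br)c2)nn1`: > 150000 nM

Compound 2 has no exact number, only a limit of the assay, > 150000 nM. Compound 1 is in the same position, with its own limit of > 150000 nM.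

The compound still to be tested, compound 3 `C/C(=C\CC/C(C)=C/CC[C@@H]1[C@@]2(C)CCC(=O)C(C)(C)[C@H]2CC[C@@]1(C)O)CC/C=C(\C)C(=O)OCc1cn(-c2ccccc2)nn1`, has hydrogen in place of bromo on an aromatic carbon, meta to a large group, so that 3-bromophenyl becomes phenyl: hydrogen in place of bromo on an aromatic carbon.

Among the compounds with values here, the one measured step that bears on this change is a step that the two limits leave unreadable from compound 1 to compound 2, which also alters only the phenyl group. Neither end of that step is a number, so it offers no size to carry over and no direction. Compound 3 is therefore expected to behave much like compound 2, with no step beyond the scatter, and a further limit is the likeliest report, given (the limit of > 150000 nM in this assay, at which 2 of the 2 values shown sit).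

The expected change is a number no higher from compound 2 to compound 3 (the limit leaves the size open). For compound 3 the estimate is 150000 nM, with an expected range from 60000 nM to 300000 nM.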

Compound 3, half-maximal inhibitory concentration: 95500 nM
For compound 3 the middle estimate is 1.6-fold (0.20 log units) above the measured one, and the stated range covers the measured number.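

In this assay, compound 3 gives the first exact number among the compounds shown, so the plain phenyl group brings this series within the measurable range, even though the number is still a weak one. Removing the bromo group now has a direction, but only a minimum size (an at least 1.5-fold lower number from compound 2 to compound 3 (0.19 log units; that floor lies within the scatter)), and replacing the 3-chloro-4-fluorophenyl group with phenyl gives the same kind of result (an at least 1.5-fold lower number from compound 1 to compound 3 (0.19 log units; that floor lies within the scatter)); since both floors lie within the scatter, the true gaps could be larger, but neither is shown to exceed the scatter. The step between compound 1 and compound 2 still cannot be read, and the halogen-bearing compounds have no exact numbers, only a limit of the assay: the limit of > 150000 nM in this assay, at which 2 of the 3 values shown sit.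

As far as these compounds go, how far compound 1 and compound 2 actually lie from compound 3 therefore remains open, and so does whether the halogens matter at all. From the compounds shown here alone, it is also open whether an amine, a methoxy group or a carboxylic acid on the aromatic ring would bring the number down further or leave it in this weak range.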